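Reversing the amide on a sulfonamide naphthalene core

The source may report more compounds than this note shows. Statements on the series, on what has been measured and on what is new or still open speak of the compounds shown alone.

Within the data shown here, compound 3 `CCOC(=O)N1CCC(NS(=O)(=O)c2ccc(NC(=O)c3ccccc3)c3ccccc23)CC1` is the one compound in this set with a measured number in an assay on L1.2 cells for binding affinity to C-C chemokine receptor type 8 (Homo sapiens) (on this read-out higher numbers stand for weaker inhibition and lower numbers for stronger inhibition), where compound 3 gives 0.17 nM. The two other compounds share its core but carry different groups on the sulfonyl sulfur. In this assay compound 1 `CCN(CC)S(=O)(=O)c1ccc(NC(=O)c2ccccc2)c2ccccc12` reaches only the assay limit of > 30000 nM. In this assay compound 2 `CN1CCN(S(=O)(=O)c2ccc(NC(=O)c3ccccc3)c3ccccc23)CC1` likewise reaches only the assay limit of > 30000 nM. The step that the two limits leave unreadable from compound 1 to compound 2 therefore cannot be read, because both values sit at the limit of > 30000 nM in this assay, at which 2 of the 3 values shown sit.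

Compound 4 `CCOC(=O)N1CCC(NS(=O)(=O)c2ccc(C(=O)Nc3ccccc3C)c3ccccc23)CC1` keeps the sulfonamide and carbamate side of compound 3 unchanged and differs only on the other side of the core: (2-methylphenyl)carbamoyl in place of benzamido on an aromatic carbon. The amide is thus turned around, and a methyl group appears on the outer aromatic ring. Among the measured compounds shown here, none of the measured steps touches this part of the molecule, and the one step that exists between compounds 1 and 2 is unreadable, so there is no measured guide to the size or direction of this change. With compound 3 as the only anchor, compound 4 is expected to lie around 3 nM, somewhere between 0.2 nM and 100 nM, which would mean a step of an 18-fold higher number from compound 3 to compound 4 (1.25 log units; beyond the scatter) from compound 3 to compound 4.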

Compound 4, inhibition constant: 5.21 nM
For compound 4 the middle estimate is 1.7-fold (0.24 log units) below the measured one; the range from low to high includes it.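

In this assay, among these compounds, replacing benzamido with (2-methylphenyl)carbamoyl gives the first step in this set that can be read, a 31-fold higher number from compound 3 to compound 4 (1.49 log units; beyond the scatter). This shows that the read-out responds to a change at the carbon para to a large group, on the side of the core away from the sulfonamide and carbamate, and that this change still leaves a measured number and not an assay limit. No measurement shown here accounts for the size of this step.

As far as these compounds go, two changes arrive together in this single step, the turned amide and the added methyl, so it remains open how much of the step belongs to each, a question that a plain phenylcarbamoyl group or a 2-methylbenzamido group at the same place could help to settle. Also open, from the compounds shown here alone, is how the number would move with other groups on the outer ring, such as a chlorine atom, a methoxy group or an amine, or with a carboxylic acid in place of the whole amide.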